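Adding a nitro group to compound 3

The source may hold more compounds than are shown below. What is called first, only, known or untested is meant among the compounds shown, and "the series" means these compounds.

Measured in a functional assay on NCI-H661 cells (Homo sapiens) for antiproliferative activity, read by MTT assay, with a stated time of 72 h; a lower number here means a stronger inhibitor, a higher number a weaker inhibitor:
- compound 1 `O=C(CCCCCCc1nc(-c2ccccc2Cl)no1)NO`: 10300 nM
- compound 2 `O=C(CCCCCCc1nc(-c2cccs2)no1)NO`: 9460 nM
- compound 3 `Nc1ccccc1NC(=O)CCCCCCc1nc(-c2ccccc2)no1`: 960 nM

Compound 3 has the lowest of the three numbers at 960 nM, and its gaps to compound 1 and compound 2 both lie beyond the scatter. The next compound, compound 4 `Nc1ccccc1NC(=O)CCCCCCc1nc(-c2ccc([N+](=O)[O-])cc2)no1`, has nitro in place of hydrogen on an aromatic carbon, para to a large group, turning phenyl into 4-nitrophenyl (nitro in place of hydrogen on an aromatic carbon).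

Among the compounds with values here, only one measured step offers any guide, and only a loose one: a 1.1-fold lower number from compound 1 to compound 2 (0.04 log units; within the scatter). That exchange of one aromatic group for another stayed within the scatter. Within the data shown here, no measured step adds a nitro, and none starts from compound 3, so the evidence is thin. On this single step, no change beyond the scatter is expected in this assay. The expected step is a 1.0-fold higher number from compound 3 to compound 4 (0.02 log units; within the scatter). Compound 4 is estimated at 1000 nM, with an expected range from 350 nM to 3000 nM.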

Compound 4, half-maximal inhibitory concentration: > 100000 nM
Compound 4 was reported as a limit; the forecaster's own chance of this, stated with the estimate: 2%; at least 100-fold (2.00 log units) between middle value and limit.
By their numbers in this assay, from the lowest: compound 3; then compounds 2 and 1 (each within the scatter of the next). At a limit, above all of these: compound 4.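

In this assay, within the data shown here, the only earlier step on the aromatic group, a 1.1-fold lower number from compound 1 to compound 2 (0.04 log units; within the scatter), lay within the scatter, which gave no sign that this part of the molecule was sensitive to change. A single nitro in place of hydrogen, para to a large group, now gives an at least 100-fold higher number from compound 3 to compound 4 (2.01 log units; beyond the scatter), so this position does not accept every group. Compound 4 sits at a limit of the assay and not at a number, so the step has no upper bound: the limit of > 100000 nM in this assay, at which 1 of the 4 values shown sits.

The compounds shown leave open whether this loss belongs to nitro itself or would follow any group at this position; an amine, a methoxy group or a single fluorine atom there could separate those two readings. They also leave open whether nitro would cost as much on the core of compound 1.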